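A few compounds are considered here, and "the series" means these few. Any claim that something is new, unique, unknown or untested is made for them only; others in the source may bear on it.

Working notes on the series. Compound 1 `COc1ccc(-c2cc(/C=C/C(=O)c3cc(OC)c(OC)c(OC)c3)nc3cc(-c4ccccc4)nn23)cc1OC`, compound 2 `COc1ccc(-c2cc(/C=C/C(=O)c3ccc(C)cc3)nc3cc(-c4ccccc4)nn23)cc1OC` and compound 3 `COc1cc(-c2cc(C(=O)/C=C/c3ccc(C)cc3)nc3cc(-c4ccccc4)nn23)cc(OC)c1OC` have been tested in a functional assay on MDA-MB-231 cells (Homo sapiens) for antiproliferative activity, read by MTT assay, with a stated time of 24 h; a higher number here means a weaker inhibitor, a lower number a stronger inhibitor. In this assay compound 1 gives 4700 nM. Compound 2 gives 19800 nM. Compound 3 gives 18600 nM.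

Compound 2 and compound 1 differ in one place: 3,4,5-trimethoxyphenyl in place of 4-methylphenyl on a carbonyl carbon. That change gives a 4.2-fold lower number from compound 2 to compound 1 (0.62 log units; beyond the scatter). Compound 3 and compound 2 differ in more than one place, and the difference between the two cores is not broken down here; their two numbers lie within the scatter of each other.

Compound 4 `COc1cc(/C=C/C(=O)c2cc(-c3cc(OC)c(OC)c(OC)c3)n3nc(-c4ccccc4)cc3n2)cc(OC)c1OC` is not yet measured. It differs from compound 3 as follows: 3,4,5-trimethoxyphenyl in place of 4-methylphenyl on a double-bonded chain carbon bound to a double-bonded chain carbon. This is the same kind of change as from compound 2 to compound 1, but not the same: there the group enters on a carbonyl carbon whose other neighbours are a double-bonded chain carbon, here on a double-bonded chain carbon bound to a double-bonded chain carbon. Beside the earlier step, a somewhat smaller lowering is expected in this assay, a 2.9-fold lower number from compound 3 to compound 4 (0.46 log units; beyond the scatter), because the only precedent is a 4.2-fold lower number from compound 2 to compound 1 (0.62 log units; beyond the scatter) at a different place, and compound 3 starts from 18600 nM. Compound 4 is therefore estimated at 6500 nM, expected between 2500 nM and 16000 nM.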

Compound 4, half-maximal inhibitory concentration: 18400 nM
Compound 4: the middle estimate sits 2.8-fold (0.45 log units) below what was measured; the whole stated range lies below it.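

In this assay, 3,4,5-trimethoxyphenyl in place of 4-methylphenyl on a double-bonded chain carbon bound to a double-bonded chain carbon gives a 1.0-fold lower number from compound 3 to compound 4 (0.00 log units; within the scatter), whereas the same exchange on a carbonyl carbon gives a 4.2-fold lower number from compound 2 to compound 1 (0.62 log units; beyond the scatter). The exchange therefore does not carry a fixed size of effect from one core to the other in this series: the same change on two cores in this assay, a 4.2-fold lower number (0.62 log units; beyond the scatter) from compound 2 to compound 1 and a 1.0-fold lower number (0.00 log units; within the scatter) from compound 3 to compound 4, 4.2-fold (0.62 log units) apart, beyond the scatter of two such steps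

This rests on a single pair on each core, and the two pairs differ both in the core and in the place of the exchange, so the data do not show which of these sets the gap, nor how the exchange would behave on any further core. The compounds shown leave open whether a phenyl ring bearing a dimethylamino group or a carboxylic acid, in place of 3,4,5-trimethoxyphenyl at either place, would move the number on either core. They also leave open whether the gap between the two steps appears in cells other than those tested here.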